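The source may hold more compounds than are shown below. What is called first, only, known or untested is meant among the compounds shown, and "the series" means these compounds.

Measured so far in an ADME assay on cells (Macrophage, Mus musculus) for cytotoxicity, read by resazurin assay, with a stated time of 3 days; a higher number here means a weaker inhibitor, a lower number a stronger inhibitor:
- compound 1 `O=C(Nc1cc(C(F)(F)F)cc(C(F)(F)F)c1)Nc1cc(Cl)ccc1O`: 13000 nM
- compound 2 `O=C(Nc1ccccc1S(=O)(=O)c1ccccc1)c1cc(Cl)ccc1O`: reported only as a limit of the assay, > 60000 nM, not a number
- compound 3 `O=C(Nc1cc(C(F)(F)F)ccc1Cl)c1cc(Cl)ccc1O`: 3500 nM

Among the two numbers in this assay compound 3 holds the lower one; compound 1 is its nearest neighbour, with a higher number, and that gap lies beyond the usual scatter. The limit for compound 2 stands apart and is not counted as a number.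

Compound 4 `O=C(Nc1cc(C(F)(F)F)ccc1Br)c1cc(Cl)ccc1O` differs from compound 3 by bromo in place of chloro on an aromatic carbon. Going by the values given here, no measured pair shows this exchange in the present set, so no size for it is known from data. The expectation is a step no larger than the scatter, in either direction. Compound 4 is estimated at 3000 nM, with a range from 1200 nM to 8000 nM, which means an expected step of a 1.2-fold lower number from compound 3 to compound 4 (0.07 log units; within the scatter).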

Compound 4, half-maximal inhibitory concentration: 2900 nM
For compound 4 the middle estimate is 1.0-fold (0.01 log units) above the measured one; measured number inside the range.
By their numbers in this assay, from the lowest: compounds 4 and 3 (each within the scatter of the next); then compound 1. At a limit, above all of these: compound 2.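

In this assay, going by these compounds alone, bromo in place of chloro, ortho to a large group and para to a trifluoromethyl group, gives a 1.2-fold lower number from compound 3 to compound 4 (0.08 log units; within the scatter) and is the first single-place comparison. Within the data shown here, the two halogens at this position therefore cannot be told apart in this read-out, which the earlier compounds, differing in more than one place, could not show. No available measurement bears on this exchange.

Open, as far as these compounds go, is how a group other than these two halogens, such as an amine, a methyl group or a carboxylic acid, would read at this position in this assay.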